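Chloro in place of trifluoromethyl: expected step

The compounds below may be only part of what the source reports. "The series", "measured", "known", "first", "only" and "open" are said of these compounds alone.

Measured in a functional assay on HT-29 cells (Homo sapiens) for antiproliferative activity, with a stated time of 48 h; on this read-out lower numbers stand for an effect already at smaller amounts and higher numbers for an effect only at larger amounts of compound:
Compound 1 `Nc1ccc(NC(=O)CCCCCCC(=O)NO)cc1`: 18000 nM
Compound 2 `O=C(CCCCCCC(=O)Nc1cccc(F)c1)NO`: 1400 nM
Compound 3 `O=C(CCCCCCC(=O)Nc1cccc(C(F)(F)F)c1)NO`: 6400 nM

Compound 3 stands in the middle of the three numbers, with compound 2 lower and compound 1 higher, both gaps beyond the scatter. Compound 4 `O=C(CCCCCCC(=O)Nc1cccc(Cl)c1)NO` carries chloro in place of trifluoromethyl on an aromatic carbon, meta to a large group: chloro in place of trifluoromethyl on an aromatic carbon. For the measured compounds named here, one measured step bears on this change: a 4.6-fold higher number from compound 2 to compound 3 (0.66 log units; beyond the scatter), with trifluoromethyl in place of fluoro. Going by the values given here, no chloro compound has been measured yet, so a partial return towards compound 2 at 1400 nM is only an expectation. A smaller step than that one, towards a lower number in this assay, is expected. The expected step is a 2.3-fold lower number from compound 3 to compound 4 (0.36 log units; beyond the scatter). For compound 4 the estimated value is 2800 nM, with an expected range of 1200 nM to 6500 nM.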

Compound 4, half-maximal effective concentration: 1000 nM
Compound 4: middle estimate off by 2.8-fold (0.45 log units), on the high side; measured number below the stated range.
By their numbers in this assay, from the lowest: compounds 4 and 2 (each within the scatter of the next); then compound 3; then compound 1.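

In this assay, the result separates trifluoromethyl from both halogens at this place on the aromatic carbon: chloro in its place gives a 6.4-fold lower number from compound 3 to compound 4 (0.81 log units; beyond the scatter), whereas chloro in place of fluoro gives a 1.4-fold lower number from compound 2 to compound 4 (0.15 log units; within the scatter). Fluoro and chloro therefore do not separate in this read-out, and only trifluoromethyl stands apart among these three groups. Nothing available explains this gap.

Still open, on these data alone, is whether bromo, methoxy or a nitrile at this same place would stay with the two halogens or with trifluoromethyl.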